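A More Polar Amide Partner and Its Expected Solubility

The source may report more compounds than this note shows. Statements on the series, on what has been measured and on what is new or still open speak of the compounds shown alone.

Of the compounds shown here, two from one series have been measured in a physicochemical assay for solubility, in phosphate buffer, measured as kinetic solubility, with a stated time of 1 h, at pH 7.4; on this read-out lower numbers stand for lower solubility and higher numbers for higher solubility. Compound 1, `COc1ccc2nc(C)c(NC(=O)C(=O)Nc3cc(C)cc(C)c3)c(O)c2c1`, gives 10000 nM. Compound 2, `COc1ccc2nc(C)cc(OCC(=O)Nc3c(C)cccc3C)c2c1`, gives 112000 nM, the higher of the two numbers; the gap between compound 1 and compound 2 lies well beyond the usual scatter of repeated measurements, so compound 2 stands clearly above compound 1 in this assay.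

Compound 3, `COc1ccc2nc(C)cc(OCC(=O)NNC(=O)c3ccncc3)c2c1`, is not yet measured. It differs from compound 2 in one place: ((pyridin-4-yl)carbonyl)amino in place of 2,6-dimethylphenyl on an amide-type nitrogen. Among the compounds with values here, no step between measured compounds shows what such a change does here, so the expectation rests on compound 2 alone. The starting point is already the highest number seen in this assay because compound 2 gives 112000 nM. The step of a 1.8-fold higher number from compound 2 to compound 3 (0.25 log units; within the scatter) is expected to be a modest rise, near the edge of the scatter. Compound 3 is estimated at 200000 nM, within a range from 70000 nM to 600000 nM.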

Compound 3, solubility: >= 375000 nM
Compound 3 gave a limit, no number (the forecaster's own chance of this, stated with the estimate: 15%); middle value at least 1.8-fold (0.27 log units) from the limit.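

Within the data shown here, the swap of 2,6-dimethylphenyl for ((pyridin-4-yl)carbonyl)amino on an amide-type nitrogen is the first single change that can be read in this assay, and it gives an at least 3.3-fold higher number from compound 2 to compound 3 (0.52 log units; beyond the scatter). Compound 3 gives >= 375000 nM, which is a limit of the assay and not a number. The step therefore shows only the smallest size the change can have, and its full size stays unknown because compound 3 sits at that limit: the limit of >= 375000 nM in this assay, at which 1 of the 3 values shown sits.

The swap replaces the whole group at once, so the compounds shown cannot separate the pyridine ring from the carbonyl and the extra nitrogen. From the compounds shown here alone, what an amine or a longer carbon chain on the same amide-type nitrogen would give also stays open.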